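Removing the ring-nitrogen phenyl from a weak antiproliferative

A few compounds are considered here, and "the series" means these few. Any claim that something is new, unique, unknown or untested is made for them only; others in the source may bear on it.

Two measured compounds frame this step. Compound 1 `O=C1COc2ccc(-c3cnc(Cl)c(NS(=O)(=O)c4ccc(F)cc4)c3)cc2N1c1ccccc1` and compound 2 `COc1cccc(N2C(=O)COc3ccc(-c4cnc5ccccc5c4)cc32)c1` were both tested in a functional assay on HeLa cells (Homo sapiens) for antiproliferative activity, read by MTT assay, with a stated time of 72 h; a lower number here means a stronger inhibitor, a higher number a weaker inhibitor. In this assay compound 1 gives 10300 nM, the lowest of the two numbers shown, while compound 2 gives 11400 nM; the two values lie within the scatter of each other, so neither can be called the stronger inhibitor.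

The untested compound 3 `O=C1COc2ccc(-c3cnc(Cl)c(NS(=O)(=O)c4ccc(F)cc4)c3)cc2N1` shares the core of compound 1 and differs from it in one place: hydrogen in place of phenyl on an amide-type nitrogen in a ring. Going by the values given here, no measured pair shows what such a change does here, and compound 2 differs from compound 1 in several places, so it offers no guide.

Compound 3 is therefore expected to land close to compound 1, with a small step toward a weaker inhibitor that may not exceed the scatter, as a 1.6-fold higher number from compound 1 to compound 3 (0.19 log units; within the scatter). The estimate for compound 3 in this assay is 16000 nM, within a range from 5000 nM to 50000 nM.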

Compound 3, half-maximal inhibitory concentration: 15600 nM
Compound 3: the middle estimate sits 1.0-fold (0.01 log units) above what was measured; low and high end bracket the measured number.
By their numbers in this assay, from the lowest: compounds 1, 2 and 3 (each within the scatter of the next).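

In this assay, going by these compounds alone, hydrogen in place of phenyl on the amide-type nitrogen in a ring gives a 1.5-fold higher number from compound 1 to compound 3 (0.18 log units; within the scatter), the first direct reading of this position. The whole phenyl ring can therefore be exchanged for a single hydrogen on this core with no difference that can be told from the scatter of repeated measurements. In this cell assay, the phenyl on that nitrogen is thus not shown to matter, though this single pair cannot establish a rule for other cores. Nothing shown here offers a measured explanation for this result.

As far as these compounds go, it remains open whether a methyl group, or a longer chain ending in an amine, on that same nitrogen would read differently. From the compounds shown here alone, it is also open whether the same exchange would read alike on the core of compound 2.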